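Methoxy added to the sulfonyl aryl ring

A few compounds are considered here, and "the series" means these few. Any claim that something is new, unique, unknown or untested is made for them only; others in the source may bear on it.

Compound 2 `COc1cccc(S(=O)(=O)NC2=NCCN2C(=S)SN2CCn3c2nsc3=S)c1` carries a 3-methoxyphenyl on the sulfonyl sulfur. In a functional assay on KYSE-510 cells (Homo sapiens) for antiproliferative activity, read by crystal violet staining, with a stated time of 96 h (a lower number here means a stronger inhibitor of growth, a higher number a weaker inhibitor of growth), compound 2 gives only a limit of the assay, >= 20000 nM. Compound 1 `Cc1ccc(S(=O)(=O)NC2=NCCN2C(=S)SN2CCn3c2nsc3=S)cc1` carries a 4-methylphenyl in that place. In this assay compound 1 likewise gives only a limit of the assay, >= 20000 nM. Among the measured compounds shown here, the single measured step, a step that the two limits leave unreadable from compound 1 to compound 2, thus gives no readable size, and what the series shows is the limit of >= 20000 nM in this assay, at which 2 of the 2 values shown sit.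

Compound 3 `COc1ccc(OC)c(S(=O)(=O)NC2=NCCN2C(=S)SN2CCn3c2nsc3=S)c1` differs from compound 2 by methoxy in place of hydrogen on an aromatic carbon. For the measured compounds named here, no measured step bears directly on this change, and the one step available is unreadable, so there is nothing to support a change beyond the scatter in either direction in this assay. Compound 3 is therefore expected to remain at the limit, with an estimate of 30000 nM and a range from 10000 nM to 100000 nM. The expected step is a step that the limit leaves unreadable from compound 2 to compound 3, nothing beyond the scatter.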

Compound 3, concentration for 50% growth inhibition: >= 20000 nM
Compound 3: only a limit was reported (the forecaster's own chance of this, stated with the estimate: 85%); the middle value lies beyond the limit too.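

No new step can be read among compound 1, compound 2 and compound 3, as each gives only a limit in this assay: the limit of >= 20000 nM in this assay, at which 3 of the 3 values shown sit.

The compounds shown leave open whether any change on the sulfonyl aryl ring or the shared core gives a readable value in this assay.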